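Fluorophenyl variation on the diaryl chain carbon, series notes

A few compounds are considered here, and "the series" means these few. Any claim that something is new, unique, unknown or untested is made for them only; others in the source may bear on it.

Measured so far:
- Compound 1, `N=C(NCCCc1c[nH]cn1)NCCC(c1cccc(F)c1)c1ccccn1`: 158 nM
- Compound 2, `N=C(NCCCc1c[nH]cn1)NCCC(c1ccccn1)c1ccccc1F`: 437 nM

Both values come from a functional assay on ileum for antagonist activity at histamine H1 receptor (Cavia porcellus); a higher number here means weaker binding, a lower number tighter binding. Among the measured compounds shown here, compound 2 gives the highest of the two numbers; its nearest neighbour is compound 1, and the step of a 2.8-fold higher number from compound 1 to compound 2 (0.44 log units; beyond the scatter) is the only difference-in-one-place comparison available, a modest rise on moving the fluorine from the 3-fluorophenyl to the 2-fluorophenyl arrangement.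

Compound 3, `N=C(NCCCc1c[nH]cn1)NCCC(c1ccc(F)c(F)c1)c1ccccn1`, is not yet measured. It differs from compound 2 as follows: 3,4-difluorophenyl in place of 2-fluorophenyl on a saturated chain carbon bound to an aromatic carbon and a saturated chain carbon. The incoming group carries a fluorine at the position that the 3-fluorophenyl of compound 1 carries, plus a second one; nothing measured shows what that second fluorine does on its own.

For the measured compounds named here, the one step that bears on the change, a 2.8-fold higher number from compound 1 to compound 2 (0.44 log units; beyond the scatter), ran upward when the fluorine left the 3-fluorophenyl arrangement; reverting to a ring fluorinated at that position is therefore expected to run back down by roughly the same amount, with the second fluorine left as an open question. Compound 3 is thus estimated at 180 nM, range 70 nM to 500 nM, meaning an expected step of a 2.4-fold lower number from compound 2 to compound 3 (0.39 log units; beyond the scatter) in this assay.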

Compound 3, dissociation constant: 85.1 nM
For compound 3 the middle estimate is 2.1-fold (0.33 log units) above the measured one, and the stated range covers the measured number.
By their numbers in this assay, from the lowest: compounds 3 and 1 (each within the scatter of the next); then compound 2.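

In this assay, 3,4-difluorophenyl in place of 2-fluorophenyl on the saturated chain carbon gives a 5.1-fold lower number from compound 2 to compound 3 (0.71 log units; beyond the scatter) and shows that this position tolerates a second ring fluorine without any loss in this read-out. The second fluorine taken alone, fluoro in place of hydrogen on an aromatic carbon, gives a 1.9-fold lower number from compound 1 to compound 3 (0.27 log units; within the scatter) and so cannot be told apart from the usual scatter of repeated measurements. Compound 2, with its 2-fluorophenyl, now stands apart from both of the other compounds, while compound 1 and compound 3 sit together, and nothing available bears on the reason for this separation.

Still open, on these data alone, is whether the placement of fluorine alone sets the level at this chain carbon, since an unsubstituted phenyl or a 4-fluorophenyl would be needed to show where the series starts and how the remaining ring position behaves. As far as these compounds go, it is equally open whether the picture is specific to fluorine or extends to larger groups, such as a 3-chlorophenyl or a 3-methoxyphenyl, on the same saturated chain carbon.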